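Benzyloxy in place of (2-isopropylphenyl)amino on the carbonyl

A few compounds are considered here, and "the series" means these few. Any claim that something is new, unique, unknown or untested is made for them only; others in the source may bear on it.

In a functional assay on Shh Light II cells (Mus musculus) for inhibition, read by a luciferase reporter (a higher number here means a weaker inhibitor, a lower number a stronger inhibitor), compound 1 `CC(C)c1ccccc1NC(=O)N1CCC(c2nc(-c3ccc4ccccc4n3)no2)CC1` gives 480 nM. Compound 2 `O=C(Nc1ccccc1C(F)(F)F)N1CCC(c2nc(-c3ccc4ccccc4n3)no2)CC1` gives 700 nM, and the step of a 1.5-fold higher number from compound 1 to compound 2 (0.16 log units; within the scatter) shows that the two stand within the scatter of each other, so neither is set apart. Compound 3 `O=C(OCc1ccccc1)N1CCC(c2nc(-c3ccc4ccccc4n3)no2)CC1` differs from compound 1 by benzyloxy in place of (2-isopropylphenyl)amino on a carbonyl carbon. For the measured compounds named here, the one measured step changes a substituent on the aromatic ring only and does not bear on exchanging the whole group at the carbonyl carbon, so no direct guide exists. Compound 3 is estimated at 1500 nM, with a range of 400 nM to 6000 nM. The expected step of a 3.1-fold higher number from compound 1 to compound 3 (0.49 log units; beyond the scatter) is toward a higher number, but uncertain.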

Compound 3, half-maximal inhibitory concentration: > 2500 nM
Compound 3 ended at the assay's limit; the forecaster's own chance of this, stated with the estimate: 15%; at least 1.6-fold (0.22 log units) between middle value and limit.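

Compound 3 reads > 2500 nM, which is a limit of this assay and not a number. Benzyloxy on the carbonyl carbon gives an at least 5.2-fold higher number from compound 1 to compound 3 (0.71 log units; beyond the scatter) and an at least 3.5-fold higher number from compound 2 to compound 3 (0.55 log units; beyond the scatter). Exchanging the whole group on the carbonyl carbon therefore moves the number beyond the scatter, whereas trifluoromethyl in place of isopropyl gave only a 1.5-fold higher number from compound 1 to compound 2 (0.16 log units; within the scatter).

The compounds shown do not separate loss of the amide hydrogen from the change in how the aromatic ring is attached; benzylamino or phenoxy on the carbonyl carbon would bear on this. As far as these compounds go, how far compound 3 lies past its limit also stays open.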